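Fluoro to hydroxy in a small growth-inhibition series

The source may report more compounds than this note shows. Statements on the series, on what has been measured and on what is new or still open speak of the compounds shown alone.

Compound 1 `CN(C)C(=O)c1cc2cnc(Nc3ccc(NC(=O)C4(C(=O)Nc5ccc(F)cc5)CC4)cc3)nc2n1C1CCCC1` gives 93.3%
Compound 2 `CN(C)C(=O)c1cc2cnc(Nc3ccc(NC(=O)C4(C(=O)Nc5ccc(Cl)cc5)CC4)cc3)nc2n1C1CCCC1` gives 52.2%
Compound 3 `CN(C)C(=O)c1cc2cnc(Nc3ccc(NC(=O)C4(C(=O)Nc5cccc(F)c5)CC4)cc3)nc2n1C1CCCC1` gives 64.2%

These values come from a functional assay on NCI-H1299 cells (Homo sapiens) for inhibition, read by CCK-8 assay, with a stated time of 72 h, tested at 1 uM; a higher number here means more inhibition of growth at the concentration tested, a lower number less inhibition of growth. Compound 3 stands in the middle, second highest of the three. Compound 4 `CN(C)C(=O)c1cc2cnc(Nc3ccc(NC(=O)C4(C(=O)Nc5cccc(O)c5)CC4)cc3)nc2n1C1CCCC1` carries hydroxy in place of fluoro on an aromatic carbon. Among the measured compounds shown here, no measured step shows this swap directly. The nearest guides are other single changes on the same ring: a number 41.1 percentage points lower from compound 1 to compound 2 (beyond the scatter), a large step, and a number 29.1 percentage points lower from compound 1 to compound 3 (beyond the scatter), a modest one. A real shift is therefore plausible, though its direction is uncertain, with only a slight lean downward. The expected step is a number 12.2 percentage points lower from compound 3 to compound 4 (beyond the scatter). Compound 4 is estimated at 52%, with an expected range from 25% to 80%.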

Compound 4, percent growth inhibition at one concentration: 77.5%
The estimate for compound 4 lay 25.5 percentage points below the measured number; the measured number falls inside the stated range.
By their numbers in this assay, from the lowest: compound 2; then compound 3; then compound 4; then compound 1.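

In this assay hydroxy in place of fluoro on this aromatic carbon gives a gain (a number 13.3 percentage points higher from compound 3 to compound 4 (beyond the scatter)), so this place tolerates a group that brings a hydrogen-bond donor and acceptor. The 3-hydroxyphenyl group also stands clear of 4-chlorophenyl (a number 25.3 percentage points higher from compound 2 to compound 4 (beyond the scatter)) but short of 4-fluorophenyl (a number 15.8 percentage points lower from compound 1 to compound 4 (beyond the scatter)). Nothing measured here explains these differences. Going by these compounds, whether an amine or methoxy at the same place would match hydroxy remains open. So does whether 4-hydroxyphenyl would match 4-fluorophenyl.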